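Chloro on the phenyl ring of compound 3

This account rests on a few compounds, and the source may have more. Where it says the series, first, only, none or still open, it means among the compounds named here.

Measured in a functional assay on HCT-116 cells (Homo sapiens) for inhibition (a lower number here means a stronger inhibitor, a higher number a weaker inhibitor), each value a limit:
compound 1 `COc1ccc2oc(=O)cc(COC(=O)C=C(C)C)c2c1`: > 10 ug/mL
compound 2 `C/C=C/C(=O)OCc1cc(=O)oc2cc(OC)c(OC)cc12`: > 10 ug/mL
compound 3 `COc1cc2oc(=O)cc(COC(=O)/C=C/c3ccccc3)c2cc1OC`: > 10 ug/mL

Compound 3 stands only as a limit, > 10 ug/mL. Going by the values given here, the series so far reads (the limit of > 10 ug/mL in this assay, at which 3 of the 3 values shown sit). Compound 4 `COc1cc2oc(=O)cc(COC(=O)/C=C/c3ccc(Cl)cc3)c2cc1OC` carries chloro in place of hydrogen on an aromatic carbon, chloro in place of hydrogen on an aromatic carbon, para to a large group. Among the compounds with values here, the only measured step that bears on this change is a step that the two limits leave unreadable from compound 2 to compound 3, which offers no size to carry over. No shift beyond the scatter is therefore expected in this assay, and no direction can be assigned. The expected change is a step that the limit leaves unreadable from compound 3 to compound 4. For compound 4 the estimated value is 12 ug/mL, with an expected range of 4 ug/mL to 30 ug/mL.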

Compound 4, half-maximal inhibitory concentration: > 10 ug/mL
Compound 4 gave a limit, no number; the forecaster's own chance of this, stated with the estimate: 70%; the middle value is on the limit's open side.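

No step can be read from compound 2 or compound 3 to compound 4, since every value is a limit: the limit of > 10 ug/mL in this assay, at which 4 of the 4 values shown sit.

The compounds shown leave open how far the chloro group, or any other change among them, shifts potency in this assay.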